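A Propyl-to-Cyclohexyl Change on the Carbonyl Carbon

The source may hold more compounds than are shown below. What is called first, only, known or untested is meant among the compounds shown, and "the series" means these compounds.

Measured in an assay on Sf9 cells for inhibition of inhibitor of nuclear factor kappa-B kinase subunit epsilon (Homo sapiens), read by ADP-Glo, with a stated time of 60 min; a higher number here means a weaker inhibitor, a lower number a stronger inhibitor:
Compound 1 `Cc1[nH]nc(N)c1-c1cccc(C(F)(F)F)c1`: > 100000 nM
Compound 2 `Cc1[nH]nc(N)c1-c1ccc(OCc2ccccc2)cc1`: 15400 nM
Compound 3 `CCCC(=O)n1nc(C)c(-c2ccc(Cl)c(Cl)c2)c1N`: > 100000 nM

Compound 3 sits at the limit of > 100000 nM in this assay, at which 2 of the 3 values shown sit, so for it only a limit and no number is known. Compound 4 `Cc1nn(C(=O)C2CCCCC2)c(N)c1-c1ccc(Cl)c(Cl)c1` differs from compound 3 in one place: cyclohexyl in place of propyl on a carbonyl carbon. Among the measured compounds shown here, no step between two measured compounds is available to weigh this change, and compound 3 itself offers no number to move from. The step of a number no higher from compound 3 to compound 4 (the limit leaves the size open) is therefore expected to be none beyond the scatter, with compound 4 most likely reported again as a limit in this assay. Compound 4 is estimated at 100000 nM, with a range from 30000 nM to 300000 nM.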

Compound 4, half-maximal inhibitory concentration: > 100000 nM
Compound 4 gave a limit, no number; the forecaster's own chance of this, stated with the estimate: 75%; the middle value lies on the limit itself.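

Compound 3 and compound 4 both gave only a limit and no number, so no step can be read between them: the limit of > 100000 nM in this assay, at which 3 of the 4 values shown sit. The compounds shown leave open whether cyclohexyl in place of propyl on a carbonyl carbon changes inhibition at all.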